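This account rests on a few compounds, and the source may have more. Where it says the series, first, only, none or still open, it means among the compounds named here.

Both compounds examined so far share one core and differ only at the amide end. Compound 1 `COc1ccc(OC)c(-c2cc(-c3ccc(C(=O)N(C)Cc4ccc(F)cc4)s3)on2)c1` carries a fluoro on the benzyl ring, and compound 2 `COc1ccc(CN(C)C(=O)c2ccc(-c3cc(-c4cc(OC)ccc4OC)no3)s2)cc1` a methoxy in its place. In a functional assay on PC-3 cells (Homo sapiens) for cytotoxicity, read by XTT assay, with a stated time of 72 h (a higher number here means a weaker inhibitor, a lower number a stronger inhibitor), compound 1 gives only a limit, > 30000 nM. In this assay compound 2 likewise gives only a limit, > 30000 nM. Within the data shown here, the one step between them, a step that the two limits leave unreadable from compound 1 to compound 2, therefore cannot be sized, since the limit of > 30000 nM in this assay, at which 2 of the 2 values shown sit, holds both values. Where compound 2 stands is thus known only as a limit, not as a number.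

Compound 3 `COc1ccc(OC)c(-c2cc(-c3ccc(C(=O)NC4CC4)s3)on2)c1` changes the amide side more deeply: cyclopropylamino in place of (4-methoxybenzyl)(methyl)amino on a carbonyl carbon. Among the measured compounds shown here, no measured step touches this change, and the only step recorded, from the fluoro to the methoxy compound, is itself unreadable. There is consequently no basis on which to expect a step of any particular size or direction in this assay, and the most likely outcome is that compound 3 again sits at the limit. The estimate for compound 3 in this assay is therefore 30000 nM, with a range of 8000 nM to 100000 nM. The step from compound 2 to compound 3 implied by this estimate is expected to be a number no higher from compound 2 to compound 3 (the limit leaves the size open).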

Compound 3, half-maximal inhibitory concentration: 7800 nM
Compound 3: the middle estimate sits 3.8-fold (0.59 log units) above what was measured, outside the stated range (below it).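

Among these compounds, compound 3 is the first compound here to give a number rather than a limit in this assay, which shows that the amide end can move the read-out, whereas the fluoro-to-methoxy change on the benzyl ring showed nothing readable. Putting cyclopropylamino in place of (4-methoxybenzyl)(methyl)amino on the carbonyl carbon gives an at least 3.8-fold lower number from compound 2 to compound 3 (0.58 log units; beyond the scatter), and putting it in place of (4-fluorobenzyl)(methyl)amino gives an at least 3.8-fold lower number from compound 1 to compound 3 (0.58 log units; beyond the scatter). Both sizes are minimum sizes and not exact ones, because the two benzyl compounds have no number of their own: the limit of > 30000 nM in this assay, at which 2 of the 3 values shown sit.

The step between the two benzyl compounds still cannot be read, and the swap removes the aromatic ring and the methyl on the nitrogen and adds the amide hydrogen all at once, with nothing shown to separate these changes. From the compounds shown here alone, whether a benzylamino group, which keeps the aromatic ring alongside the amide hydrogen, or a plain methylamino group would also give a number in this assay stays open.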